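Amide side-chain variation around the shared core

The compounds below may be only part of what the source reports. "The series", "measured", "known", "first", "only" and "open" are said of these compounds alone.

Of the compounds shown here, three sharing one core have been read in an assay on isolated protein for inhibition of NEDD8-activating enzyme E1 regulatory subunit (Homo sapiens), read by Western blot, with stated times of 10 min and 30 min, tested at 25 uM; on this read-out higher numbers stand for more inhibition at the one concentration tested (going by the name of the read-out) and lower numbers for less inhibition. Compound 1 `CCOc1nc2cccc(C(=O)NCCCN(C)C)c2n1Cc1ccc(-c2ccccc2-c2nnn[nH]2)cc1` gives 29.5% and compound 2 `CCOc1nc2cccc(C(=O)NCCCOC)c2n1Cc1ccc(-c2ccccc2-c2nnn[nH]2)cc1` gives 27.9%; the step of a number 1.6 percentage points lower from compound 1 to compound 2 (within the scatter) lies within the scatter, so these two are not ordered against each other. Compound 3 `CCOc1nc2cccc(C(=O)NCc3ccccc3)c2n1Cc1ccc(-c2ccccc2-c2nnn[nH]2)cc1` gives 48.9%, the highest of the three numbers, with both a number 19.4 percentage points higher from compound 1 to compound 3 (beyond the scatter) and a number 21 percentage points higher from compound 2 to compound 3 (beyond the scatter) beyond the scatter.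

Compound 4 `CCOc1nc2cccc(C(=O)NCCCCc3ccccc3)c2n1Cc1ccc(-c2ccccc2-c2nnn[nH]2)cc1` is not yet measured. (3-phenylpropyl in place of phenyl on a saturated chain carbon bound to an amide-type nitrogen). Among the compounds with values here, no measured step covers a change of this kind: the two steps into compound 3 exchange one group for another on the same chain carbon, while here the ring is kept and a 3-phenylpropyl link is inserted. Those two steps only show that the phenyl-bearing compound 3 stands above compounds 1 and 2, which bear dimethylamino or methoxy chains. Compound 4 keeps the ring, so a step of about a number 6.9 percentage points lower from compound 3 to compound 4 (within the scatter) is expected, within the scatter. Compound 4 is therefore estimated at 42%, in the range 22% to 62%.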

Compound 4, a percentage reported as inhibition, at one concentration (the size of the read-out at that concentration, not a potency): 64.6%
Compound 4: the middle estimate sits 22.6 percentage points below what was measured; the whole stated range lies below it.
By their numbers in this assay, from the lowest: compounds 2 and 1 (each within the scatter of the next); then compound 3; then compound 4.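

In this assay, the phenyl ring alone does not settle the read-out at this position: with the ring kept, 3-phenylpropyl in place of phenyl gives a number 15.7 percentage points higher from compound 3 to compound 4 (beyond the scatter) and so the chain that carries the ring matters as well. The end of the chain also counts, since benzyl in place of methoxy gives a number 36.7 percentage points higher from compound 2 to compound 4 (beyond the scatter) and benzyl in place of dimethylamino gives a number 35.1 percentage points higher from compound 1 to compound 4 (beyond the scatter) at the saturated chain carbon three bonds along the chain from the amide-type nitrogen. No measurement shown here explains why these steps arise.

Still open, as far as these compounds go, is whether 2-phenylethyl would fall between phenyl and 3-phenylpropyl, and whether a longer chain such as 4-phenylbutyl would carry the number further. Also open, from the compounds shown here alone, is whether a cyclohexyl or pyridyl ring at the chain end would serve as the phenyl ring does.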